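The source may report more compounds than this note shows. Statements on the series, on what has been measured and on what is new or still open speak of the compounds shown alone.

Measured compounds:
- compound 1, `CCn1c(CNc2ccccc2)nnc1SCC(=O)Nc1ccccc1`: > 1000 nM
- compound 2, `CCOC(=O)c1ccc(NC(=O)CSc2nnc(CSCc3ccccc3)n2CC)cc1`: 7600 nM
- compound 3, `CCn1c(CNc2ccccc2)nnc1SCc1nc2cc(C)ccc2o1`: > 1000 nM

These three compounds were tested in an assay on isolated protein for inhibition of long-chain fatty acid transport protein 1 (Homo sapiens); on this read-out lower numbers stand for stronger inhibition and higher numbers for weaker inhibition. For compound 1 the result is not a number but a limit of the assay, > 1000 nM. Compound 3 also sits at a limit, > 1000 nM. Where the readings stop at a limit, the true strength of the compound stays unknown; this is the situation described by the limit of > 1000 nM in this assay, at which 2 of the 3 values shown sit. Only compound 2 carries a measured number, 7600 nM, in this assay. So compound 1 cannot be ranked against the others: its reading says only that it did not reach the measurable range.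

Compound 4, `CCn1c(CNc2ccccc2)nnc1SCC(=O)Nc1ccc(C(C)=O)cc1`, has not yet been measured. It differs from compound 1 in one place: acetyl in place of hydrogen on an aromatic carbon. Going by the values given here, no step between two measured compounds follows this kind of change, so the size and direction of the effect must be guessed. A small group added at the edge of the molecule is expected to move this assay little, if at all, beyond the usual scatter. The step from compound 1 to compound 4 is therefore estimated as a step that the limit leaves unreadable from compound 1 to compound 4, with the strong possibility that compound 4 also ends at a limit. Compound 4 is expected to give roughly 5000 nM, between 1500 nM and 20000 nM.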

Compound 4, half-maximal inhibitory concentration: > 1000 nM
Compound 4 was reported as a limit (the forecaster's own chance of this, stated with the estimate: 50%); the middle value does not contradict the limit.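

In this assay compound 4 reads > 1000 nM and this is a limit, not a number. Compound 1 also ends at a limit, so no step can be read between compound 1 and compound 4 because neither has a number: the limit of > 1000 nM in this assay, at which 3 of the 4 values shown sit. As far as these compounds go, whether acetyl in place of hydrogen changes the inhibition at all stays open.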